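Swapping an Aryl Group for a Styryl Chain

A few compounds are considered here, and "the series" means these few. Any claim that something is new, unique, unknown or untested is made for them only; others in the source may bear on it.

Compound 2 `Cc1cc(O)c(C2=NN(c3ccc(S(N)(=O)=O)cc3)C(c3ccccc3Cl)C2)cc1Cl` was tested in a functional assay on CAKI-1 cells (Homo sapiens) for antiproliferative activity, with a stated time of 48 h (a higher number here means that more compound is tolerated, a lower number that less compound is tolerated), where compound 2 gives 8950 nM. Among the compounds with values here, this is the lowest of the two numbers measured so far, though its only neighbour, compound 1 `Cc1cc(O)c(C2=NN(c3ccc(S(N)(=O)=O)cc3)C(c3ccccc3O)C2)cc1Cl`, sits close: compound 1 gives 16600 nM, and the step of a 1.9-fold lower number from compound 1 to compound 2 (0.27 log units; within the scatter) is within the usual scatter, so the two cannot be told apart on these data.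

Compound 3 `Cc1cc(O)c(C2=NN(c3ccc(S(N)(=O)=O)cc3)C(/C=C/c3ccccc3)C2)cc1Cl` has not been measured. It differs from compound 2 by 2-phenylethenyl in place of 2-chlorophenyl on a saturated ring carbon. Within the data shown here, the only measured step, from compound 1 to compound 2, also changed the group on this same saturated ring carbon and moved the number by an amount that stays within the scatter. That step swapped one substituted phenyl for another, whereas the change to compound 3 replaces the whole ring by a 2-phenylethenyl chain, so it does not speak directly to the new change. With nothing pointing either way, no step beyond the scatter is expected in this assay. Compound 3 is therefore estimated at 9000 nM, with a range from 3000 nM to 30000 nM, meaning an expected step of a 1.0-fold higher number from compound 2 to compound 3 (0.00 log units; within the scatter).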

Compound 3, concentration lethal to 50% of the cells: > 100000 nM
Compound 3 ended at the assay's limit; the forecaster's own chance of this, stated with the estimate: 10%; middle value at least 11-fold (1.04 log units) away from the limit.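

In this assay, the result for compound 3 is a limit of the assay and not a number: the limit of > 100000 nM in this assay, at which 1 of the 3 values shown sits. Replacing the 2-chlorophenyl group on the saturated ring carbon with 2-phenylethenyl gives an at least 11-fold higher number from compound 2 to compound 3 (1.04 log units; beyond the scatter), and replacing the 2-hydroxyphenyl group there with the same chain gives an at least 6.0-fold higher number from compound 1 to compound 3 (0.77 log units; beyond the scatter). The earlier exchange of one substituted phenyl for another could not show this, since a 1.9-fold lower number from compound 1 to compound 2 (0.27 log units; within the scatter) stayed within the scatter, whereas these steps show that the group on this carbon can clearly change how much compound the cells tolerate.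

The compounds shown leave open whether the double bond, the longer link to the phenyl ring or the loss of the ring substituent drives this step, and a saturated 2-phenylethyl chain would help to separate the first of these from the others. They also leave open how much smaller or differently built groups on this carbon, such as methyl or dimethylamino, would behave.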